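This account rests on a few compounds, and the source may have more. Where it says the series, first, only, none or still open, it means among the compounds named here.

Of the compounds shown here, three that share one core have been measured in a functional assay on A549 cells (Homo sapiens) for inhibition, read by MTT assay, with a stated time of 72 h; on this read-out lower numbers stand for stronger inhibition and higher numbers for weaker inhibition. Compound 1 `COc1cc2c(Oc3ccc(NC(=O)c4nn(-c5ccccc5)c(=O)cc4C)cc3F)ccnc2cc1OCCCN1CCCCC1` gives 150 nM. Compound 2 `COc1cc2c(Oc3ccc(NC(=O)c4nn(-c5ccccc5OC(F)(F)F)c(=O)cc4C)cc3F)ccnc2cc1OCCCN1CCCCC1`, which carries trifluoromethoxy in place of hydrogen on an aromatic carbon, gives 120 nM, and a 1.3-fold lower number from compound 1 to compound 2 (0.10 log units; within the scatter). Compound 3 `COc1cc2c(Oc3ccc(NC(=O)c4nn(-c5cccc(F)c5)c(=O)cc4C)cc3F)ccnc2cc1OCCCN1CCCCC1`, with fluoro in place of hydrogen on an aromatic carbon, gives 250 nM; this is the highest of the three numbers, though a 1.7-fold higher number from compound 1 to compound 3 (0.22 log units; within the scatter), while a 2.1-fold higher number from compound 2 to compound 3 (0.32 log units; beyond the scatter). Compound 4 `COc1ccc(-n2nc(C(=O)Nc3ccc(Oc4ccnc5cc(OCCCN6CCCCC6)c(OC)cc45)c(F)c3)c(C)cc2=O)cc1` has not yet been measured; it differs from compound 3 in that (4-methoxyphenyl in place of 3-fluorophenyl on an aromatic nitrogen). For the measured compounds named here, two measured steps bear on this change, both altering the ring that sits on that aromatic nitrogen, and each of them stays small. Swapping one such ring for another has so far moved this assay only modestly, so a small step downward for compound 4, or none beyond the scatter, is expected. Compound 4 is therefore estimated at 170 nM, with a range from 80 nM to 350 nM. For compound 4 this means an expected 1.5-fold lower number from compound 3 to compound 4 (0.17 log units; within the scatter).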

Compound 4, half-maximal inhibitory concentration: 1500 nM
For compound 4 the middle estimate is 8.8-fold (0.95 log units) below the measured one; the whole stated range lies below it.
By their numbers in this assay, from the lowest: compounds 2, 1 and 3 (each within the scatter of the next, the first and the last beyond it); then compound 4.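

In this assay, for the compounds shown here, the ring on the aromatic nitrogen proves less forgiving than the earlier compounds suggested: 4-methoxyphenyl brings a 10-fold higher number from compound 1 to compound 4 (1.00 log units; beyond the scatter) against the plain phenyl ring, whereas the trifluoromethoxy and fluoro changes stayed within the scatter of compound 1. The same group brings a 6.0-fold higher number from compound 3 to compound 4 (0.78 log units; beyond the scatter) and a 13-fold higher number from compound 2 to compound 4 (1.10 log units; beyond the scatter) against the two other substituted rings, so compound 4 stands apart from all three. This position therefore does respond to what the ring carries, and the response depends on the group rather than on swapping a ring as such.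

The compounds shown leave open whether the methoxy group itself or its place on the ring matters, which a 2-methoxyphenyl or a 4-fluorophenyl ring on the same nitrogen would help to separate. Nothing available here bears on why the number rises.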